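The source may hold more compounds than are shown below. What is called first, only, known or untested is meant among the compounds shown, and "the series" means these compounds.

Compound 1 `COc1ccc(NC(=O)NC2CC(C)(C)Oc3ccc(Cl)cc32)cc1` is known in a functional assay (aorta) with Rattus norvegicus as the target (a lower number here means that less compound is needed, a higher number that more compound is needed for the effect), only as a limit, > 30000 nM. Compound 2 `COc1ccc(NC(=O)NC2CC(C)(C)Oc3ccc(Br)cc32)cc1` likewise gives only a limit in this assay, > 10000 nM. Within the data shown here, the single measured step, a step that the two limits leave unreadable from compound 1 to compound 2, stays unreadable because the limit of > 30000 nM in this assay, at which 1 of the 2 values shown sits, and the limit of > 10000 nM in this assay, at which 1 of the 2 values shown sits, sit at both of its ends. Compound 3 `CC1(C)CC(NC(=O)Nc2ccccc2Cl)c2cc(Cl)ccc2O1` arises from compound 1 by 2-chlorophenyl in place of 4-methoxyphenyl on an amide-type nitrogen. Among the measured compounds shown here, no measured step bears on this change, so neither its size nor its direction can be drawn from the data. Compound 3 is expected to sit near an estimated 30000 nM, within 5000 nM to 200000 nM, with an expected step of a number no higher from compound 1 to compound 3 (the limit leaves the size open) not beyond the scatter.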

Compound 3, half-maximal effective concentration: > 300000 nM
Compound 3: no number, only a limit; the forecaster's own chance of this, stated with the estimate: 75%; at least 10-fold (1.00 log units) between middle value and limit.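

Compound 1 and compound 3 are both known only as limits in this assay, and the step between them cannot be read. The compounds shown leave open whether 2-chlorophenyl in place of 4-methoxyphenyl changes the concentration needed.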